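Chloro for hydrogen on the aryl group of a coumarin ether

A few compounds are considered here, and "the series" means these few. Any claim that something is new, unique, unknown or untested is made for them only; others in the source may bear on it.

Measured compounds:
Compound 1 `C#CCOc1ccc2oc(=O)ccc2c1` — "not determined" (no result reported)
Compound 2 `O=c1ccc2cc(OCc3cc(-c4ccccc4)no3)ccc2o1` — "not determined" (no result reported)
Compound 3 `O=c1ccc2cc(OCc3cc(-c4cccc5ccccc45)no3)ccc2o1` — 47200 nM

The set was tested in a functional assay on COLO 205 cells (Homo sapiens) for cytotoxicity, read by MTT assay, with a stated time of 48 h; a lower number here means a stronger inhibitor, a higher number a weaker inhibitor. Compound 1 `C#CCOc1ccc2oc(=O)ccc2c1` carries no reported result in this assay, and the same holds for compound 2 `O=c1ccc2cc(OCc3cc(-c4ccccc4)no3)ccc2o1`, so compound 2 stands without a number of its own; two of the three measured entries give no single figure. Only compound 3 `O=c1ccc2cc(OCc3cc(-c4cccc5ccccc45)no3)ccc2o1` has a value: in this assay compound 3 gives 47200 nM, a weak inhibitor. For the measured compounds named here, no step between two measured compounds can be compared here.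

The new entry, compound 4 `O=c1ccc2cc(OCc3cc(-c4cccc(Cl)c4)no3)ccc2o1`, differs from compound 2 by chloro in place of hydrogen on an aromatic carbon. Going by the values given here, since compound 2 has no number, no step size can be computed, and the expectation rests on the single measured analogue. The nearest point of comparison is compound 3 with its 47200 nM, which shows that an aromatic substituent of this kind on the ether arm leaves the compound weak. Compound 4 is therefore expected to fall in the same weak region, with an estimated value of 40000 nM and a range from 12000 nM to 130000 nM; a limit rather than a number is a real possibility.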

Compound 4, half-maximal inhibitory concentration: 32500 nM
Compound 4: middle estimate off by 1.2-fold (0.09 log units), on the high side; the measured number falls inside the stated range.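

In this assay, for the compounds shown here, compound 2 carries no single number, so no step from compound 2 to compound 4 can be read. The compounds shown leave open whether chloro in place of hydrogen on the phenyl group changes the cytotoxicity at all. No other data shown here bear on this result.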